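The source may report more compounds than this note shows. Statements on the series, on what has been measured and on what is new or still open speak of the compounds shown alone.

Of the compounds shown here, three have been measured in a physicochemical assay for metabolic stability, read by LC-MS, in simulated gastric fluid, with a stated time of 15 min, tested at 50 uM; on this read-out higher numbers stand for a more stable compound and lower numbers for a less stable compound. Compound 1 `Cc1ccn2c(C(=O)NCc3ccc(Cl)cc3)c(C)nc2c1` gives 94.3%. Compound 3 `Cc1cc(C)c(COC(=O)c2coc(-c3ccccc3)n2)c(C)c1` gives 5.6%. Compound 2 `O=C(Oc1ccccc1N1CCCC1)c1coc(-c2ccccc2)n1` gives 0.1%, the lowest of the three numbers; its gap to compound 3 lies within the scatter, while its gap to compound 1 lies well beyond it.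

Compound 4 `O=C(Oc1ccccc1)c1coc(-c2ccccc2)n1` is not yet measured. It differs from compound 2 in one place: hydrogen in place of pyrrolidin-1-yl on an aromatic carbon.

Since compound 2 and compound 3 both sit near the bottom of the scale, the step of a number 2.9 percentage points higher from compound 2 to compound 4 (within the scatter) is expected to be small, most likely no change beyond the scatter in this assay. Compound 4 is accordingly estimated at 3%, within a range from 0.1% to 25%.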

Compound 4, percent of the compound remaining: 0.2%
Compound 4: middle estimate off by 2.8 percentage points, on the high side; the range from low to high includes it.
By their numbers in this assay, from the lowest: compounds 2, 4 and 3 (each within the scatter of the next); then compound 1.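

In this assay, hydrogen in place of pyrrolidin-1-yl on this aromatic carbon, ortho to a large group, gives a number 0.1 percentage points higher from compound 2 to compound 4 (within the scatter). Compound 4, with no group there, stays near the bottom of the scale, so the low number of compound 2 does not depend on pyrrolidin-1-yl at this place. Nothing measured here explains why these numbers are so low.

From the compounds shown here alone, whether a methoxy group or a fluorine on this aromatic carbon would move the number remains open. So does whether an amide in place of the ester of compound 4 would raise it.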